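This account rests on a few compounds, and the source may have more. Where it says the series, first, only, none or still open, it means among the compounds named here.

The series is a set of peptide-like compounds tested in an assay on isolated protein for inhibition of Trypsin (Homo sapiens), read by fluorescence, with a stated time of 15 min, tested at 50 uM; on this read-out higher numbers stand for more inhibition at the one concentration tested (going by the name of the read-out) and lower numbers for less inhibition. Compound 1 `N=C(N)NCCC[C@H](NC(=O)c1ccccc1)C(=O)N(CCCCN)CC(=O)N[C@@H](C(N)=O)c1ccccc1` gives 10.6% in this assay. Compound 2 `CC(NC(=O)[C@H](CCCCN)NC(=O)[C@H](CCCNC(=N)N)NC(=O)c1ccccc1)(C(N)=O)c1ccccc1` returns only a limit of the assay, <= 5%, and not a number. Compound 3 `CN(C(=O)c1ccccc1)[C@@H](CCCNC(=N)N)C(=O)N[C@@H](CCCCN)C(=O)N[C@@H](C(N)=O)c1ccccc1` likewise returns a limit of the assay, <= 5%. Among the compounds with values here, compound 2 therefore stands at the limit of <= 5% in this assay, at which 2 of the 3 values shown sit, with compound 1 the only compound of the three that gives a number, and how far compound 2 lies from compound 1 cannot be sized from the values shown.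

Compound 4 `CCC(NC(=O)[C@H](CCCCN)NC(=O)[C@H](CCCNC(=N)N)NC(=O)c1ccccc1)(C(N)=O)c1ccccc1` has not yet been measured in this assay. It differs from compound 2 in one place: methyl in place of hydrogen on a saturated chain carbon, two bonds along the chain from an amide-type nitrogen, an aromatic carbon and a carbonyl carbon. Within the data shown here, no step between measured compounds repeats this change, so nothing measured here shows what a methyl in that place does in this assay. The expected step from compound 2 to compound 4 is a number no lower from compound 2 to compound 4 (the limit leaves the size open), that is, none beyond the usual scatter. Compound 4 is estimated at 5% in this assay, with a range from 0% to 15%, and it is expected that the assay most likely reports a limit for compound 4 again rather than a number.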

Compound 4, a percentage reported as inhibition, at one concentration (the size of the read-out at that concentration, not a potency): 8.7%
For compound 4 the middle estimate is 3.7 percentage points below the measured one; the measured number falls inside the stated range.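

Within the data shown here, the methyl-to-ethyl change is the first step to test a methyl in place of hydrogen on a saturated chain carbon, two bonds along the chain from an amide-type nitrogen, an aromatic carbon and a carbonyl carbon, and in this assay it reads as a number at least 3.7 percentage points higher from compound 2 to compound 4 (that floor lies within the scatter). Compound 4, with its 1-carbamoyl-1-phenylpropyl group, gives a real number of 8.7%, which shows that the added methyl leaves the read-out measurable, although the size of the step cannot be told apart from the scatter. Compound 2, by contrast, stands at a limit of the assay and not at a number: the limit of <= 5% in this assay, at which 2 of the 4 values shown sit.

The compounds shown leave open how far the read-out at this carbon would move with a longer chain such as propyl, or with a hydroxymethyl or an aminomethyl group in place of the ethyl. They also leave open whether the true gap on this change lies beyond the scatter, since one end of the step is only a limit.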